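A piperazine substituent on the aniline of compound 1

A few compounds are considered here, and "the series" means these few. Any claim that something is new, unique, unknown or untested is made for them only; others in the source may bear on it.

Compound 1 `CN(c1ncccc1CNc1nc(Nc2ccccc2)nc2[nH]cc(F)c12)S(C)(=O)=O` is tested in a functional assay on SMMC-7721 cells (Homo sapiens) for inhibition, read by MTT assay, with a stated time of 48 h; a lower number here means a stronger inhibitor, a higher number a weaker inhibitor; in that assay compound 1 gives > 100000 nM, which is a limit of the assay rather than a number. Its two measured relatives share the same core and differ only at the aryl group attached to the amine. Compound 2 `COc1cccc(Nc2nc(NCc3cccnc3N(C)S(C)(=O)=O)c3c(F)c[nH]c3n2)c1C` gives > 100000 nM in this assay, again a limit. Compound 3 `CC(=O)Nc1cccc(Nc2nc(NCc3cccnc3N(C)S(C)(=O)=O)c3c(F)c[nH]c3n2)c1` gives 16000 nM in this assay. The step of an at least 6.2-fold lower number from compound 1 to compound 3 (0.79 log units; beyond the scatter) therefore shows that adding a group to that aryl ring can move the number into the measurable range, and the step of an at least 6.2-fold lower number from compound 2 to compound 3 (0.79 log units; beyond the scatter) points the same way, while the step that the two limits leave unreadable from compound 1 to compound 2 cannot be read because of the limit of > 100000 nM in this assay, at which 2 of the 3 values shown sit.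

Compound 4 `CN1CCN(c2ccc(Nc3nc(NCc4cccnc4N(C)S(C)(=O)=O)c4c(F)c[nH]c4n3)cc2)CC1` differs from compound 1 by 4-methylpiperazin-1-yl in place of hydrogen on an aromatic carbon. Among the measured compounds shown here, no measured step adds exactly this group, so the expectation leans on the one readable addition, the step from compound 1 to compound 3. On that basis compound 4 is expected to gain a similar amount, an estimated step of an at least 5.0-fold lower number from compound 1 to compound 4 (0.69 log units; beyond the scatter). Compound 4 is accordingly estimated at 20000 nM in this assay, within a range from 4000 nM to 100000 nM.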

Compound 4, half-maximal inhibitory concentration: 13900 nM
Compound 4: the middle estimate sits 1.4-fold (0.16 log units) above what was measured; low and high end bracket the measured number.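

The 4-methylpiperazin-1-yl group gives an at least 7.1-fold lower number from compound 1 to compound 4 (0.85 log units; beyond the scatter) in this assay, so a measurable number on this ring no longer rests on the acetamido group of compound 3 alone. The new group is also of a different kind: a six-membered non-aromatic ring with 2 hetero atoms, 7 heavy atoms in all, placed on an aromatic carbon para to a large group, and this place accepts it without the number being lost to the assay limit. The pattern does not cover every substituted ring, since compound 2, with its 3-methoxy-2-methylphenyl group, gives > 100000 nM, which is a limit of the assay.

The true size of the gain stays open, because compound 1 itself is known only as a limit, and so the step has a lower bound but no upper one: the limit of > 100000 nM in this assay, at which 2 of the 4 values shown sit. The compounds shown also leave open whether the whole piperazine ring matters, or whether a simple dimethylamino group, a morpholine ring or a carboxylic acid on that same aromatic carbon would move the number in the same way.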